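Thiazole carboxylic acid replaces anthranilic acid on the amide

The compounds below may be only part of what the source reports. "The series", "measured", "known", "first", "only" and "open" are said of these compounds alone.

Measured compounds:
Compound 1 `COc1ccc(-c2nc3cc(F)c(F)cc3n2[C@H](C(=O)N[C@H]2CC[C@H](C(=O)O)CC2)C2CCCCC2)c(Cl)n1`: 1100 nM
Compound 2 `O=C(O)c1ccccc1NC(=O)C(C1CCCCC1)n1c(-c2ccc(Cl)cc2)nc2cc(F)c(F)cc21`: > 40000 nM
Compound 3 `O=C(O)c1ccc(NC(=O)[C@H](C2CCCCC2)n2c(-c3ccc(Cl)cc3)nc3cc(F)c(F)cc32)c(C(F)(F)F)c1`: 50 nM

In a functional assay for agonist activity at Bile acid receptor (Homo sapiens), read by a luciferase reporter (on this read-out lower numbers stand for an effect already at smaller amounts and higher numbers for an effect only at larger amounts of compound), compound 1 gives 1100 nM and compound 3 gives 50 nM. For compound 2 this assay reports only a limit, > 40000 nM. Compound 2 therefore stands at the limit of > 40000 nM in this assay, at which 1 of the 3 values shown sits, and no number places it relative to the other two. Compound 4 `Cc1nc(NC(=O)C(C2CCCCC2)n2c(-c3ccc(Cl)cc3)nc3cc(F)c(F)cc32)sc1C(=O)O` differs from compound 2 by 5-carboxy-4-methyl-1,3-thiazol-2-yl in place of 2-carboxyphenyl on an amide-type nitrogen. Going by the values given here, no step between two measured compounds covers this change, so the expectation rests on the limit for compound 2 and the numbers of compound 1 and compound 3 alone. A gain beyond the usual scatter is expected, an at least 13-fold lower number from compound 2 to compound 4 (1.12 log units; beyond the scatter), with wide uncertainty. Compound 4 is estimated at 3000 nM, in a range from 300 nM to 30000 nM.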

Compound 4, half-maximal effective concentration: 10400 nM
For compound 4 the middle estimate is 3.5-fold (0.54 log units) below the measured one; the range from low to high includes it.
By their numbers in this assay, from the lowest: compound 3; then compound 1; then compound 4. At a limit, above all of these: compound 2.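

In this assay, 5-carboxy-4-methyl-1,3-thiazol-2-yl in place of 2-carboxyphenyl on an amide-type nitrogen gives an at least 3.8-fold lower number from compound 2 to compound 4 (0.58 log units; beyond the scatter). This step starts from a limit, not a number, so it sets only a lower bound on the size of the change: the limit of > 40000 nM in this assay, at which 1 of the 4 values shown sits. Compound 4 thus shows that, with this core, a measurable response can be recovered by changing only the acid-bearing ring on the amide nitrogen.

From the compounds shown here alone, how much of the step belongs to the methyl group and how much to the thiazole ring stays open. Whether a tetrazole could stand in for the carboxylic acid on this ring also remains unanswered.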